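The source may report more compounds than this note shows. Statements on the series, on what has been measured and on what is new or still open speak of the compounds shown alone.

Measured so far in a physicochemical assay for lipophilicity; on this read-out higher numbers stand for higher lipophilicity and lower numbers for lower lipophilicity:
- compound 1 `CCn1cnc2c(-c3ccc(F)c(Oc4ccnc(C)c4)c3)cnnc21`: 2.6
- compound 2 `CCn1cnc2c(-c3ccnc(OC)c3)cnnc21`: 1.5
- compound 3 `CCn1cnc2c(-c3ccnc(Oc4ccccc4)c3)cnnc21`: 2.6

Compound 3 stands level with compound 1, the two sharing the highest number of the three. Compound 4 `CCn1cnc2c(-c3ccnc(Oc4cccc(S(=O)(=O)CC)c4)c3)cnnc21` differs from compound 3 in one place: ethylsulfonyl in place of hydrogen on an aromatic carbon. Within the data shown here, the only measured step, a number 1.10 log units higher from compound 2 to compound 3 (beyond the scatter), is large and came with phenyl in place of methyl on an oxygen on an aromatic ring. Among the measured compounds shown here, that is a different exchange, so it bears on this one only loosely, and no measured step adds an ethylsulfonyl. A moderate fall in this assay is therefore expected, though without a measured precedent. The estimated change is a number 0.70 log units lower from compound 3 to compound 4 (beyond the scatter). For compound 4 the estimate is 1.9, with an expected range from 1.4 to 2.4.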

Compound 4, distribution coefficient: 1.6
For compound 4 the middle estimate is 0.30 log units above the measured one, within the range that was stated.
By their numbers in this assay, from the lowest: compounds 2 and 4 (each within the scatter of the next); then compounds 1 and 3 (each within the scatter of the next).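

In this assay, among these compounds, ethylsulfonyl in place of hydrogen on an aromatic carbon, meta to a large group, gives a number 1.00 log units lower from compound 3 to compound 4 (beyond the scatter) and is the first measured change on this ring of carbon only. It shows that a single group placed here can move the read-out beyond the scatter. No evidence at hand accounts for the fall. The compounds shown leave open how an amine, a carboxylic acid or a methylsulfonyl would compare at this place. Going by these compounds, whether ethylsulfonyl gives a step of like size elsewhere on this ring also remains open.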